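From phenyl to 4-hydroxyphenyl in a growth inhibition series

A few compounds are considered here, and "the series" means these few. Any claim that something is new, unique, unknown or untested is made for them only; others in the source may bear on it.

Compound 1 `c1ccc(-c2ccc(-c3ccc(-c4nc5ccccc5[nH]4)cc3)cc2)cc1` gives 41200 nM
Compound 2 `Cc1ccc2[nH]c(-c3ccc(-c4ccc(-c5cccc(Cl)c5)cc4)cc3)nc2c1` gives 2670 nM
Compound 3 `Fc1ccc(-c2ccc(-c3ccc(-c4nc5ccccc5[nH]4)cc3)cc2)cc1` gives 41200 nM

In a functional assay on PC-3 cells (Homo sapiens) for inhibition, read by sulforhodamine B assay (on this read-out higher numbers stand for weaker inhibition of growth and lower numbers for stronger inhibition of growth), compound 1 stands level with compound 3 and the two share the highest number of the three, while compound 2 has the lowest. Compound 4 `Oc1ccc(-c2ccc(-c3ccc(-c4nc5ccccc5[nH]4)cc3)cc2)cc1` is compound 1 with hydroxy in place of hydrogen on an aromatic carbon and nothing else altered. Within the data shown here, the one measured step of this kind, with fluoro as the entering group, is no change at the digits printed from compound 1 to compound 3 (within the scatter) and it lies within the scatter. Hydroxy is a different group, so this is only a loose guide. The expected step is a 1.4-fold lower number from compound 1 to compound 4 (0.14 log units; within the scatter) and so none beyond the scatter is foreseen. In this assay compound 4 is estimated at 30000 nM within an expected range of 12000 nM to 50000 nM overall.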

Compound 4, concentration for 50% growth inhibition: 47000 nM
The estimate for compound 4 lay 1.6-fold (0.19 log units) below the measured number; measured number inside the range.
By their numbers in this assay, from the lowest: compound 2; then compounds 1, 3 and 4 (each within the scatter of the next).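

In this assay, hydroxy on this aromatic carbon, para to a large group, gives a 1.1-fold higher number from compound 1 to compound 4 (0.06 log units; within the scatter), and hydroxy in place of fluoro gives a 1.1-fold higher number from compound 3 to compound 4 (0.06 log units; within the scatter). Hydroxy, with its hydrogen-bond donor and acceptor, is thus a second entering group at this position that leaves the number within the scatter of the hydrogen parent, and the three compounds cannot be told apart here. Nothing available accounts for this result. From the compounds shown here alone, whether an amine or a carboxylic acid at this position would shift the number stays open. So does whether a longer chain, such as methoxy or ethoxy, would.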